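Series notes: the step from compound 2 to compound 3

The source may hold more compounds than are shown below. What is called first, only, known or untested is meant among the compounds shown, and "the series" means these compounds.

Compound 1 `Cn1cncc1CN1CC(N(CC2CCN(C(=O)c3ccccc3)CC2)S(=O)(=O)c2ccccn2)Cc2cc(C#N)ccc21` and compound 2 `Cn1cncc1CN1CC(N(CC2CCN(C(=O)CC(F)(F)F)CC2)S(=O)(=O)c2ccccn2)Cc2cc(C#N)ccc21` share one core and differ in a single group on a carbonyl carbon. In an ADME assay on Caco-2 cells (Homo sapiens) for permeability, in the apical to basolateral direction (on this read-out higher numbers stand for higher permeability and lower numbers for lower permeability), compound 1 gives 0.5 10^-6 cm/s, and compound 2 gives 0.5 10^-6 cm/s; the step of no change at the digits printed from compound 1 to compound 2 (within the scatter) lies within the scatter. For the measured compounds named here, compound 2 thus stands level with compound 1 on this read-out, and no other measured compound exists to set it against.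

Compound 3 `CCS(=O)(=O)N1CCC(CN(C2Cc3cc(C#N)ccc3N(Cc3cncn3C)C2)S(=O)(=O)c2ccccn2)CC1` is not yet measured. Its difference from compound 2 is ethylsulfonyl in place of (2,2,2-trifluoroethyl)carbonyl on an amine nitrogen in a ring. Going by the values given here, no measured step covers this exact exchange on the ring amine nitrogen. Among the compounds with values here, the only step known, no change at the digits printed from compound 1 to compound 2 (within the scatter), exchanged one group for another at a carbonyl carbon and left the read-out unchanged within the scatter, so nothing in the data points to a direction. The expected step of no change at the digits printed from compound 2 to compound 3 (within the scatter) is therefore none beyond the scatter. Compound 3 is estimated at 0.5 10^-6 cm/s in this assay, with a range from 0.2 10^-6 cm/s to 1.2 10^-6 cm/s that allows for the usual spread of repeated measurements.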

Compound 3, apparent permeability: 0.1 10^-6 cm/s
For compound 3 the middle estimate is 5.0-fold (0.70 log units) above the measured one; measured number below the stated range.
By their numbers in this assay, from the lowest: compound 3; then compounds 1 and 2 (each within the scatter of the next).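

On an amine nitrogen in a ring, the group does move the read-out in this assay: ethylsulfonyl in place of (2,2,2-trifluoroethyl)carbonyl gives a 5.0-fold lower number from compound 2 to compound 3 (0.70 log units; beyond the scatter) and ethylsulfonyl in place of benzoyl gives a 5.0-fold lower number from compound 1 to compound 3 (0.70 log units; beyond the scatter) as the two steps now on record. For the compounds shown here, the earlier exchange, which altered only the group on the carbonyl carbon and kept the carbonyl itself, gave no change at the digits printed from compound 1 to compound 2 (within the scatter) and so showed no sensitivity here; the new steps are the first to replace that carbonyl, and both starting groups, aromatic or fluorinated, lead to the same printed value in compound 3. No measurement in hand bears on the reason for this difference.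

The compounds shown leave open whether the sulfonyl link or the ethyl group attached to it carries the step, since the two change together in compound 3. A phenylsulfonyl group, which would pair directly with the benzoyl of compound 1, or a propionyl group, which would pair with the ethylsulfonyl of compound 3, would separate the two.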